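A few compounds are considered here, and "the series" means these few. Any claim that something is new, unique, unknown or untested is made for them only; others in the source may bear on it.

Compound 1 `COc1cccc(Nc2nccc(-c3ccc(C)o3)n2)c1` gives 1500 nM in a functional assay for inhibition, with Homo sapiens as the target; a higher number here means a weaker inhibitor, a lower number a stronger inhibitor.
Compound 2 `Cc1cccc(Nc2nccc(-c3ccc(C)o3)n2)c1` gives 2000 nM in this assay.

Going by the values given here, compound 2 and compound 1 lie within the scatter of each other, as the only measured step shows: a 1.3-fold higher number from compound 1 to compound 2 (0.12 log units; within the scatter). Compound 3 `Cc1cccc(Nc2nccc(-c3ccncc3)n2)c1` differs from compound 2 in one place: pyridin-4-yl in place of 5-methylfuran-2-yl on an aromatic carbon. Among the compounds with values here, the one measured step concerns methyl in place of methoxy and leaves the 5-methylfuran-2-yl untouched, so no measured step bears on this change. With nothing to go on, the expected step is no change at the digits printed from compound 2 to compound 3 (within the scatter), in no direction beyond the scatter. Compound 3 is therefore estimated at 2000 nM, with a range from 500 nM to 8000 nM.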

Compound 3, half-maximal inhibitory concentration: 8800 nM
Beside the measured number, compound 3's estimate is 4.4-fold (0.64 log units) below it, outside the stated range (above it).
By their numbers in this assay, from the lowest: compounds 1 and 2 (each within the scatter of the next); then compound 3.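

Unlike the earlier swap of methyl for methoxy, this change moves the number beyond the scatter in this assay: pyridin-4-yl in place of 5-methylfuran-2-yl gives a 4.4-fold higher number from compound 2 to compound 3 (0.64 log units; beyond the scatter), a weaker inhibitor. The two groups have the same printed counts of heavy atoms and hydrogen-bond acceptors but differ in ring size and hetero atom, so this position is sensitive to which ring it carries. Nothing measured here explains the loss.

Going by these compounds, whether ring size or the hetero atom matters remains open. A phenyl or thiophen-2-yl group at this position could help separate the two.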